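Swapping the small ring on a fused core

The source may report more compounds than this note shows. Statements on the series, on what has been measured and on what is new or still open speak of the compounds shown alone.

Of the compounds shown here, three sharing one fused core have been tested in a functional assay on the whole organism with Rattus norvegicus as the target; a higher number here means that more compound is needed for the effect, a lower number that less compound is needed. Compound 1, `CCCc1c(OC)nc2nc(-c3noc(C)n3)cn2c1C`, gives 5 mg/kg. Compound 2, `C=CCc1c(OC)nc2nc(-c3noc(C)n3)cn2c1C`, gives 10 mg/kg, which puts it second highest of the three numbers; the step of a 2.0-fold higher number from compound 1 to compound 2 (0.30 log units; within the scatter) lies within the scatter. Within the data shown here, compound 3, `CCCc1nnc(-c2cn3c(C)c(CC)c(OC)nc3n2)o1`, gives 50 mg/kg, a number beyond the scatter above that of compound 2, but compound 3 differs from compound 2 in more than one place, so its value shows only that a differently built compound can need more.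

Compound 4, `C=CCc1c(OC)nc2nc(-c3nc(C)cs3)cn2c1C`, is the next to be measured. It differs from compound 2 in this way: 4-methyl-1,3-thiazol-2-yl in place of 5-methyl-1,2,4-oxadiazol-3-yl on an aromatic carbon. Among the measured compounds shown here, no measured step touches this position. For the measured compounds named here, the only recorded step, from compound 1 to compound 2, concerns the side chain, not the ring that is exchanged here, so it gives no direct guidance. In the absence of a comparable step, the expected change is small: the step from compound 2 to compound 4 is estimated as a 1.5-fold higher number from compound 2 to compound 4 (0.18 log units; within the scatter), with the possibility of a higher number left open by compound 3. Compound 4 is therefore expected to give 15 mg/kg, within a range from 5 mg/kg to 50 mg/kg.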

Compound 4, minimum effective dose: > 50 mg/kg
Compound 4 gave a limit, no number; the forecaster's own chance of this, stated with the estimate: 10%; middle value at least 3.3-fold (0.52 log units) away from the limit.
By their numbers in this assay, from the lowest: compounds 1 and 2 (each within the scatter of the next); then compound 3.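

Before this result, the only step between compounds differing in one place concerned the side chain, and it stayed within the scatter, so nothing yet showed how this position on the five-membered aromatic ring with 2 nitrogen responds to change. In this assay compound 4 gives > 50 mg/kg, which is a limit of the assay and not a number. Exchanging the ring matters here, since 4-methyl-1,3-thiazol-2-yl in place of 5-methyl-1,2,4-oxadiazol-3-yl gives an at least 5.0-fold higher number from compound 2 to compound 4 (0.69 log units; beyond the scatter), and the full size of that step stays unknown because the reading stops at the limit: the limit of > 50 mg/kg in this assay, at which 1 of the 4 values shown sits.

The exchange swaps a ring with 3 hetero atoms, including oxygen, for one with 2, including sulfur, and the compounds shown cannot tell which part of that swap accounts for the step. They also leave open how a plain phenyl ring or a primary amide would fare on this aromatic carbon, and whether 4-methyl-1,3-thiazol-2-yl would give a similar step on the propyl compound 1.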